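The source may hold more compounds than are shown below. What is called first, only, known or untested is meant among the compounds shown, and "the series" means these compounds.

The three measured compounds share one core and differ only in the aromatic group carried on it. Compound 1 `CC(C)Oc1cccc(-c2ccc(C(=O)N(Cc3cccc(OCCCCCC(=O)O)c3)C(C)C)cc2)c1` in an ADME assay on Raji cells (Homo sapiens) for cytotoxicity, read by CellTiter-Glo and resazurin assay, with a stated time of 72 h (on this read-out lower numbers stand for an effect already at smaller amounts and higher numbers for an effect only at larger amounts of compound), gives only a limit, > 26000 nM. Compound 2 `CC(C)N(Cc1cccc(OCCCCCC(=O)O)c1)C(=O)c1ccc(-c2ccsc2)cc1` in this assay likewise gives a limit, > 26000 nM. Compound 3 `CC(C)N(Cc1cccc(OCCCCCC(=O)O)c1)C(=O)c1ccc(-c2ccc3[nH]ccc3c2)cc1` also reaches only a limit, > 26000 nM. Because every value shown sits at the limit of > 26000 nM in this assay, at which 3 of the 3 values shown sit, none of the steps among the three can be sized: a step that the two limits leave unreadable from compound 1 to compound 2, a step that the two limits leave unreadable from compound 1 to compound 3 and a step that the two limits leave unreadable from compound 2 to compound 3 all remain unreadable. Compound 3 therefore stands among values that are all limits, with no number that would separate it from compound 1 or compound 2.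

Compound 4 `COc1cc(OC)cc(-c2ccc(C(=O)N(Cc3cccc(OCCCCCC(=O)O)c3)C(C)C)cc2)c1` is not yet measured. It differs from compound 3 by 3,5-dimethoxyphenyl in place of 1H-indol-5-yl on an aromatic carbon. Among the compounds with values here, the three measured steps bear on this change only in that each of them, unreadable as it is, shows no compound of the set with an effect inside the tested range. From those steps no direction or size can be read, so the step that the limit leaves unreadable from compound 3 to compound 4 is expected to be nominal only, with compound 4 most likely landing again at a limit. Compound 4 is estimated at 30000 nM, with a range from 10000 nM to 100000 nM.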

Compound 4, half-maximal effective concentration: > 26000 nM
Compound 4 gave a limit, no number (the forecaster's own chance of this, stated with the estimate: 85%); the middle value does not contradict the limit.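

In this assay compound 4 gives only a limit (> 26000 nM). Its steps from compound 1, compound 2 and compound 3 therefore cannot be read, and no number separates the four compounds: the limit of > 26000 nM in this assay, at which 4 of the 4 values shown sit.
The compounds shown leave open whether any aromatic group on the shared core gives an effect within the tested range.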